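Acyl variation on the piperazine amide of the benzimidazole series

The source may hold more compounds than are shown below. What is called first, only, known or untested is meant among the compounds shown, and "the series" means these compounds.

Measured so far:
compound 1, `COc1ccc(C(=O)N2CCN(Cc3nc4ccccc4n3Cc3cccc(C)c3)CC2)cc1`, 55.5%
compound 2, `Cc1cccc(Cn2c(CN3CCN(C(=O)C4CCCCC4)CC3)nc3ccccc32)c1`, 31.9%
compound 3, `Cc1ccc(C(=O)N2CCN(Cc3nc4ccccc4n3Cc3cccc(C)c3)CC2)cc1`, 64.9%

All three share one core and differ only in the group on the carbonyl carbon of the piperazine amide. In an assay on isolated protein for inhibition of aldehyde dehydrogenase 1A1 (Homo sapiens), read by spectrophotometry, tested at 10 uM (a lower number here means less inhibition, a higher number more inhibition at the concentration tested (going by the name of the read-out)), compound 3 stands highest of the three numbers, though its gap to compound 1 lies within the scatter; only its gap to compound 2 is beyond it.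

The next compound, compound 4, `CC(=O)N1CCN(Cc2nc3ccccc3n2Cc2cccc(C)c2)CC1`, is not yet measured. It differs from compound 3 at the same carbonyl carbon:
methyl in place of 4-methylphenyl on a carbonyl carbon

Among the measured compounds shown here, two measured steps bear on this site. The step of a number 23.6 percentage points lower from compound 1 to compound 2 (beyond the scatter) shows a modest loss when the ring on the carbonyl carbon is no longer aromatic, and the step of a number 33 percentage points higher from compound 2 to compound 3 (beyond the scatter) shows a large gain in the opposite direction. Both point the same way: an aromatic ring on the carbonyl carbon goes with more inhibition in this assay. Compound 4 carries no ring there at all, so a drop beyond the scatter is expected, a number 39.9 percentage points lower from compound 3 to compound 4 (beyond the scatter), plausibly at least as large as the measured steps. The estimate for compound 4 in this assay is 25%, with a range from 8% to 45%.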

Compound 4, a percentage reported as inhibition, at one concentration (the size of the read-out at that concentration, not a potency): 70.3%
For compound 4 the middle estimate is 45.3 percentage points below the measured one, outside the stated range (above it).
By their numbers in this assay, from the lowest: compound 2; then compounds 1, 3 and 4 (each within the scatter of the next, the first and the last beyond it).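

In this assay, the aromatic ring on the carbonyl carbon proves not to be needed: the change from (4-methylphenyl)carbonyl to acetyl stays within the scatter (a number 5.4 percentage points higher from compound 3 to compound 4 (within the scatter)), so the link between an aromatic ring and more inhibition does not hold across the four compounds. Compound 2, with cyclohexyl, now stands apart, as methyl gives a large step up from it (a number 38.4 percentage points higher from compound 2 to compound 4 (beyond the scatter)), while the same methyl also clears 4-methoxyphenyl by a modest step (a number 14.8 percentage points higher from compound 1 to compound 4 (beyond the scatter)), so the ring-bearing compound 1 sits beyond the scatter from the ringless acetyl amide. Nothing measured on these compounds accounts for the low number of the cyclohexyl amide or for the high number of the acetyl amide.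

Open, on these data alone, is whether the read-out holds when methyl gives way to a longer chain such as propyl, which would show where between methyl and cyclohexyl the fall sets in. Also open, as far as these compounds go, are how a carboxylic acid or an amine on this carbonyl carbon would read, and whether compound 3 and compound 4 would stay together as potencies, since this read-out comes from one concentration only.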